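The compounds below may be only part of what the source reports. "The series", "measured", "known", "first", "only" and "open" are said of these compounds alone.

Working notes on the series.

Compound 1 `CCCCc1ccc(-c2cc(=O)c3c(o2)C(CC)(CC)C(=O)C(CC)=C3O)cc1` is the reference point. In a functional assay on KB cells (Homo sapiens) for antiproliferative activity, read by sulforhodamine B assay, with a stated time of 3 days (on this read-out higher numbers stand for an effect only at larger amounts of compound and lower numbers for an effect already at smaller amounts), compound 1 gives 111 uM, the highest of the two plain numbers in hand. Compound 2 `CCC1=C(O)c2c(oc(-c3ccc(C(F)(F)F)cc3)cc2=O)C(CC)(CC)C1=O` gives 35.7 uM in this assay, so that a 3.1-fold lower number from compound 1 to compound 2 (0.49 log units; beyond the scatter). Compound 3 `CCC1=C(O)c2c(oc(-c3ccc(SC)cc3)cc2=O)C(CC)(CC)C1=O` returns in this assay only a limit, > 52.1 uM. That limit, (the limit of > 52.1 uM in this assay, at which 1 of the 3 values shown sits), leaves the comparison open: a step that the limit leaves unreadable from compound 1 to compound 3, and an at least 1.4-fold higher number from compound 2 to compound 3 (0.16 log units; that floor lies within the scatter).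

Compound 4 `CCC1=C(O)c2c(oc(-c3ccc(F)cc3)cc2=O)C(CC)(CC)C1=O` has not been measured. Against compound 1 the change is fluoro in place of butyl on an aromatic carbon. Among the measured compounds shown here, the only fully readable step at this position, a 3.1-fold lower number from compound 1 to compound 2 (0.49 log units; beyond the scatter), also replaces butyl with a small substituent and gives a modest drop in the number. The step to compound 3 cannot be sized, so a single readable step carries the expectation. A shift in this assay toward a lower number than compound 1 is plausible, but of a size that may not clear the scatter.

Compound 4 is therefore expected to give about 60 uM in this assay, within 25 uM to 140 uM. The expected step is a 1.9-fold lower number from compound 1 to compound 4 (0.27 log units; within the scatter).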

Compound 4, concentration for half-maximal effect: 33 uM
Compound 4: the middle estimate sits 1.8-fold (0.26 log units) above what was measured; low and high end bracket the measured number.
By their numbers in this assay, from the lowest: compounds 4 and 2 (each within the scatter of the next); then compound 1.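

The fluoro result makes the drop from butyl more than a single case: a 3.4-fold lower number from compound 1 to compound 4 (0.53 log units; beyond the scatter) in this assay, so two different small replacements at this aromatic carbon now give a lower number than butyl, while methylsulfanyl cannot be placed in that comparison. Fluoro and trifluoromethyl, the two readable replacements, are not separated, a 1.1-fold lower number from compound 2 to compound 4 (0.03 log units; within the scatter), so this series gives no sign that the choice between them matters in this read-out. The step with methylsulfanyl leaving, an at least 1.5-fold lower number from compound 3 to compound 4 (0.19 log units; that floor lies within the scatter), is only a floor, and compound 3 stands as a limit: the limit of > 52.1 uM in this assay, at which 1 of the 4 values shown sits.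

The compounds shown leave open whether the number moves gradually with chain length, as only butyl represents the chains here, and a methyl, an ethyl or a longer chain such as hexyl at the same carbon would test this. They also leave open how a plain hydrogen, an amine or a carboxylic acid would read at this place, and whether the lower numbers hold with the rest of the core of compound 1 changed.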